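A Second Fluoro Group on the Aromatic Ring

A few compounds are considered here, and "the series" means these few. Any claim that something is new, unique, unknown or untested is made for them only; others in the source may bear on it.

Compound 1 `C#CCNC1CCc2c(SCc3cccc(F)c3)cccc21`: 1480 nM
Compound 2 `C#CCNC1CCc2c(SCCc3cccc(F)c3)cccc21`: 4300 nM
Compound 3 `C#CCNC1CCc2c(SCCc3ccc(F)c(F)c3)cccc21`: 3240 nM

All three were tested in an assay on isolated protein for inhibition of Amine oxidase [flavin-containing] B (Homo sapiens); on this read-out lower numbers stand for stronger inhibition and higher numbers for weaker inhibition. Compound 1 gives the lowest number, and its gaps to compound 3 and to compound 2 are both beyond the scatter. The difference between the core of compound 1 and the core of compound 2 is not broken down here. Compound 2 and compound 3 differ by one change, (fluoro in place of hydrogen on an aromatic carbon), which brought a 1.3-fold lower number from compound 2 to compound 3 (0.12 log units; within the scatter).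

Compound 4 `C#CCNC1CCc2c(SCc3ccc(F)c(F)c3)cccc21` is not yet measured. It differs from compound 1 by the same change, (fluoro in place of hydrogen on an aromatic carbon), at the same place. Because compound 2 to compound 3 showed only a 1.3-fold lower number from compound 2 to compound 3 (0.12 log units; within the scatter), a similarly small step is expected, namely a 1.2-fold lower number from compound 1 to compound 4 (0.09 log units; within the scatter). For compound 4 the estimated value in this assay is 1200 nM, expected between 500 nM and 2800 nM.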

Compound 4, half-maximal inhibitory concentration: 2650 nM
For compound 4 the middle estimate is 2.2-fold (0.34 log units) below the measured one; measured number inside the range.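

Adding the second fluoro group gave a 1.8-fold higher number from compound 1 to compound 4 (0.25 log units; within the scatter), a step no larger than the differences seen between repeated measurements. Set beside the same change on the other core, this step does not stand apart: the same change on two cores in this assay, a 1.3-fold lower number (0.12 log units; within the scatter) from compound 2 to compound 3 and a 1.8-fold higher number (0.25 log units; within the scatter) from compound 1 to compound 4, 2.4-fold (0.38 log units) apart, within the scatter of two such steps. The two cores therefore give no sign that the change behaves differently from one to the other, but two small steps do not prove that it carries over, and neither shows a real effect of the fluoro group in this assay.

As far as these compounds go, whether a chloro or methoxy group in place of the second fluoro group would give a step beyond the scatter stays open. So does the result of a longer chain between the sulfur and the aromatic ring.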